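A Fluoro Swap on a Compound at the Assay Limit

This account rests on a few compounds, and the source may have more. Where it says the series, first, only, none or still open, it means among the compounds named here.

Compound 1 `COc1ccccc1N1CCN(CC(O)CN2C(=O)C3=C(SCCS3)C2=O)CC1` and compound 2 `O=C1C2=C(SCCS2)C(=O)N1CCCCN1CCN(c2ccccc2)CC1` were both tested in an ADME assay on MDBK cells (Bos taurus) for cytotoxicity, read by MTT assay, with a stated time of 120 h (a lower number here means that less compound is tolerated, a higher number that more compound is tolerated), and neither gave an exact number. In this assay compound 1 gives > 100000 nM as a limit of the assay, not a number. In this assay compound 2 gives > 100000 nM as a limit of the assay, not a number. Compound 2 therefore stands at the limit of > 100000 nM in this assay, at which 2 of the 2 values shown sit, and offers only a limit as a starting point.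

Compound 3 `O=C1C2=C(SCCS2)C(=O)N1CCCCN1CCN(c2ccc(F)cc2)CC1` differs from compound 2 by one change, phenyl to 4-fluorophenyl, with fluoro in place of hydrogen on an aromatic carbon, para to a large group, counted as fluoro in place of hydrogen on an aromatic carbon in the structures. Within the data shown here, no measured pair shows what such a change does in this assay here, so no step beyond the usual scatter is expected, in either direction. The estimated step of a number no higher from compound 2 to compound 3 (the limit leaves the size open) is expected to stay within that scatter. Compound 3 is estimated at 100000 nM with an expected range of 50000 nM to 200000 nM. A limit of the assay rather than an exact number is expected for compound 3.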

Compound 3, half-maximal cytotoxic concentration: > 100000 nM
Compound 3: only a limit was reported; the forecaster's own chance of this, stated with the estimate: 80%; the middle value sits exactly at the limit.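

Compound 3, like compound 2, gives a limit of the assay and not a number, so no step between compound 2 and compound 3 can be read in this assay: the limit of > 100000 nM in this assay, at which 3 of the 3 values shown sit.

The compounds shown leave open how much of each one the cells tolerate, and whether fluoro in place of hydrogen on an aromatic carbon changes that at all.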